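Thiosemicarbazone Growth Inhibition: From Phenyl to Pyrrole

The compounds below may be only part of what the source reports. "The series", "measured", "known", "first", "only" and "open" are said of these compounds alone.

Measured compounds:
- compound 1, `CC1=CC[C@H](C(C)(C)NC(=S)N/N=C/c2ccccc2)CC1`: > 100000 nM
- compound 2, `CC1=CC[C@H](C(C)(C)NC(=S)N/N=C/c2ccccc2[N+](=O)[O-])CC1`: > 100000 nM

Compound 1 carries a phenyl group on the carbon that is double-bonded to nitrogen. In a functional assay on NCI/ADR-RES cells (Homo sapiens) for inhibition, read by sulforhodamine B assay, with a stated time of 48 h (on this read-out lower numbers stand for stronger inhibition of growth and higher numbers for weaker inhibition of growth), compound 1 reaches only a limit, > 100000 nM, so no actual number is known for it. Compound 2 adds a nitro in place of hydrogen on an aromatic carbon, and in this assay compound 2 also stops at a limit, > 100000 nM. The step that the two limits leave unreadable from compound 1 to compound 2 therefore cannot be read, because of the limit of > 100000 nM in this assay, at which 2 of the 2 values shown sit.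

Compound 3, `CC1=CC[C@H](C(C)(C)NC(=S)N/N=C/c2ccc[nH]2)CC1`, is the yet unmeasured case. It differs from compound 1 by 1H-pyrrol-2-yl in place of phenyl on a carbon with a double bond to nitrogen. For the measured compounds named here, no measured step bears directly on swapping a six-membered carbon ring for a five-membered ring with one hetero atom, and the one step that is known is itself unreadable. With both known values sitting at the limit, the expectation for compound 3 is that it too shows weak growth inhibition, estimated at 100000 nM with a range from 30000 nM to 300000 nM. This estimate implies a step of a number no higher from compound 1 to compound 3 (the limit leaves the size open), which is expected to stay within scatter.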

Compound 3, concentration for total growth inhibition: > 100000 nM
Compound 3: a limit, no number; the forecaster's own chance of this, stated with the estimate: 75%; the middle value sits exactly at the limit.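

No size can be read for the step from compound 1 to compound 3, since both compounds give only a limit and not a number: the limit of > 100000 nM in this assay, at which 3 of the 3 values shown sit.

The compounds shown leave open how strongly any of them inhibits growth in this assay and how phenyl and 1H-pyrrol-2-yl would compare on a readable number.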